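The source may hold more compounds than are shown below. What is called first, only, known or untested is meant among the compounds shown, and "the series" means these compounds.

Compound 1 `COc1ccccc1/C=C1\CCC/C(=C\c2cccc(OC)c2OC)C1=O` carries a 2-methoxyphenyl group on each of its two double-bonded chain carbons. In a functional assay on A549 cells (Homo sapiens) for cytotoxicity, read by MTT assay, with a stated time of 72 h (on this read-out lower numbers stand for stronger inhibition and higher numbers for weaker inhibition), compound 1 gives only a limit of the assay, > 20000 nM, and no number. Compound 2 `COc1cccc(/C=C2\CCC/C(=C\c3ccc(Cl)cc3Cl)C2=O)c1OC` likewise gives only a limit in this assay, > 20000 nM. Compound 3 `COc1cccc(/C=C2\CCC/C(=C\c3cc(OC)c(OC)c(OC)c3)C2=O)c1OC`, in contrast, gives a measured value in this assay of 5900 nM. Within the data shown here, the one measured step that touches a change at this position, a step that the two limits leave unreadable from compound 1 to compound 2, cannot be read in size, because the limit of > 20000 nM in this assay, at which 2 of the 3 values shown sit, is where both its ends sit. Compound 4 `COc1cccc(/C=C2\CCC/C(=C\c3ccc(O)c(Cl)c3)C2=O)c1OC` differs from compound 1 by 3-chloro-4-hydroxyphenyl in place of 2-methoxyphenyl on a double-bonded chain carbon bound to a double-bonded ring carbon. Among the measured compounds shown here, no measured step tells how a 3-chloro-4-hydroxyphenyl group behaves here, and compound 3 shows only that a substituted phenyl group at this position can bring a readable value. The step of an at least 1.6-fold lower number from compound 1 to compound 4 (0.22 log units; that floor lies within the scatter) is therefore expected to be small and uncertain in direction, with a real chance that compound 4 again gives only a limit. Compound 4 is estimated at 12000 nM in this assay, within a range from 4000 nM to 40000 nM.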

Compound 4, half-maximal inhibitory concentration: > 20000 nM
Compound 4: only a limit was reported; the forecaster's own chance of this, stated with the estimate: 45%; middle value at least 1.6-fold (0.22 log units) away from the limit.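

Compound 4 gives only a limit in this assay, > 20000 nM. The steps from compound 1 and from compound 2 to compound 4 cannot be read, because both ends of each sit at the same limit: the limit of > 20000 nM in this assay, at which 3 of the 4 values shown sit. The compounds shown leave open how compound 1, compound 2 and compound 4 differ from one another.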